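Swapping the distal aryl group: from a fluorophenyl to a furan

This account rests on a few compounds, and the source may have more. Where it says the series, first, only, none or still open, it means among the compounds named here.

Compound 2 `COc1cc(CC(O)c2ccc(-c3ccccc3F)cc2)c([N+](=O)[O-])cc1OC` was tested in an ADME assay on HeLa Rh cells (Homo sapiens) for cytotoxicity, read by microscopy (on this read-out higher numbers stand for lower toxicity in this test and lower numbers for higher toxicity in this test), and gives 5000 nM. Compound 1 `COc1cc(CC(O)c2ccc(-c3cccc([N+](=O)[O-])c3)cc2)c([N+](=O)[O-])cc1OC` gives 5500 nM in this assay, and the change a 1.1-fold lower number from compound 1 to compound 2 (0.04 log units; within the scatter) shows that replacing one aryl group on the distal ring by another left the read-out essentially unchanged; the two numbers sit within the usual scatter of each other.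

Compound 3 `COc1cc(CC(O)c2ccc(-c3ccoc3)cc2)c([N+](=O)[O-])cc1OC` has not yet been measured. It differs from compound 2 in one place: furan-3-yl in place of 2-fluorophenyl on an aromatic carbon. Going by the values given here, the only measured step that bears on this change is the aryl swap from compound 1 to compound 2, which was within the scatter. On that basis the step from compound 2 to compound 3 in this assay is expected to be no change at the digits printed from compound 2 to compound 3 (within the scatter), with no movement beyond the scatter in either direction. Compound 3 is therefore estimated at 5000 nM, within a range from 2500 nM to 10000 nM.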

Compound 3, half-maximal cytotoxic concentration: 5300 nM
The estimate for compound 3 lay 1.1-fold (0.03 log units) below the measured number, and the stated range covers the measured number.
By their numbers in this assay, from the lowest: compounds 2, 3 and 1 (each within the scatter of the next).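

Until now, only six-membered aromatic rings of carbon had been seen at this place, para to a large group. Furan-3-yl is a smaller, five-membered aromatic ring with 1 hetero atom and 1 hydrogen-bond acceptor, yet this assay gives a 1.1-fold higher number from compound 2 to compound 3 (0.03 log units; within the scatter) and a 1.0-fold lower number from compound 1 to compound 3 (0.02 log units; within the scatter), both within the scatter. So, across these three compounds, neither the ring size nor the oxygen atom separates the numbers, and nothing available explains this result.

On these data alone, all three groups at this place are aromatic rings, so it remains open whether the numbers would hold with an amine, a carboxylic acid or a longer chain there. These compounds also leave open whether a change elsewhere on the shared core would move the numbers more than these ring swaps do.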